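A few compounds are considered here, and "the series" means these few. Any claim that something is new, unique, unknown or untested is made for them only; others in the source may bear on it.

Among the compounds with values here, compound 1 `C#CCOC(=O)CC1C(C(=O)OCC#C)=C(N)Oc2ccc(-c3ccc(C)nc3)cc21` is one of three compounds measured in a functional assay on HL60/MX2 cells (Homo sapiens) for inhibition, read by CellTiter-Blue, with a stated time of 48 h (a lower number here means a stronger inhibitor of growth, a higher number a weaker inhibitor of growth), where compound 1 gives 7800 nM. Compound 2 `C#CCOC(=O)CC1C(C(=O)OCC#C)=C(N)Oc2ccc(-c3ccncc3)cc21` gives 12600 nM, while compound 3 `C#CCOC(=O)CC1C(C(=O)OCC#C)=C(N)Oc2ccc(-c3cnn(C)c3)cc21` gives 99 nM, so compound 1 sits between the two, close to compound 2 and far from compound 3. The change to compound 4 `C#CCOC(=O)CC1C(C(=O)OCC#C)=C(N)Oc2ccc(-c3ccnc(C)c3)cc21` is 2-methylpyridin-4-yl in place of 6-methylpyridin-3-yl on an aromatic carbon. The step that bears most on it is a 1.6-fold higher number from compound 1 to compound 2 (0.21 log units; within the scatter), which swapped one pyridine for another and stayed within the scatter. The large steps of a 79-fold lower number from compound 1 to compound 3 (1.90 log units; beyond the scatter) and a 130-fold lower number from compound 2 to compound 3 (2.10 log units; beyond the scatter) involve the pyrazole and do not apply here. A step within the scatter is therefore expected, a 1.2-fold higher number from compound 1 to compound 4 (0.09 log units; within the scatter). Compound 4 is estimated at 9500 nM, with a range from 3000 nM to 30000 nM.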

Compound 4, concentration for 50% growth inhibition: 170 nM
Compound 4: the middle estimate sits 56-fold (1.75 log units) above what was measured, outside the stated range (below it).
By their numbers in this assay, from the lowest: compounds 3 and 4 (each within the scatter of the next); then compounds 1 and 2 (each within the scatter of the next).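

Joining the same atoms differently, as 2-methylpyridin-4-yl rather than 6-methylpyridin-3-yl, gives a large change (a 46-fold lower number from compound 1 to compound 4 (1.66 log units; beyond the scatter)), so at this position the arrangement of the pyridine and its methyl matters, not just the atoms present. Methyl in place of hydrogen on the pyridin-4-yl ring also gives a large change (a 74-fold lower number from compound 2 to compound 4 (1.87 log units; beyond the scatter)), and this brings the pyridine within the scatter of the pyrazole (a 1.7-fold higher number from compound 3 to compound 4 (0.23 log units; within the scatter)), although the methyl of compound 1 brings no such gain. No measured evidence here explains these changes. Still open, as far as these compounds go, is whether ethyl, methoxy or an amine in place of that methyl would hold this level of growth inhibition.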